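The source may hold more compounds than are shown below. What is called first, only, known or untested is meant among the compounds shown, and "the series" means these compounds.

Compound 1 `C[C@H]1[C@@H](O)[C@@H](O)[C@H](CO)NN1C(=O)OCc1ccccc1` and compound 2 `C[C@H]1[C@@H](O)[C@@H](O)[C@H](CNC(=O)[C@@H](N)CCCCN)NN1C(=O)OCc1ccccc1` share the same core and were examined in an assay on isolated protein for inhibition of tissue alpha-L-fucosidase (Bos taurus), tested at 1 mM; a higher number here means more inhibition at the concentration tested (going by the name of the read-out), a lower number less inhibition. In this assay, for the measured compounds named here, compound 1 gives 35%, the lowest of the two numbers known. Going by the values given here, compound 2 gives 77% in this assay, and the single measured step, a number 42 percentage points higher from compound 1 to compound 2 (beyond the scatter), concerns the exchange of a hydroxy for a ((1,5-diaminopentyl)carbonyl)amino group.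

Among the compounds with values here, compound 3 `C[C@@H]1[C@@H](O)[C@@H](O)[C@H](CO)NN1C(=O)OCc1ccccc1` is not yet measured. the two compounds have the same atoms and bonds and differ only in configuration as drawn: 1 of 4 stereo elements differ; a stereocentre at a saturated ring carbon is drawn S in compound 1 and R in compound 3 No measured step concerns a change in configuration alone, so the step from compound 1 to compound 2 does not bear on this change. On the numbers available, compound 3 is expected to give 30% in this assay, within a range from 5% to 60%. This estimate means a step of a number 5 percentage points lower from compound 1 to compound 3 (within the scatter), which is expected to lie within the scatter of such measurements.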

Compound 3, a percentage reported as inhibition, at one concentration (the size of the read-out at that concentration, not a potency): 27%
Estimate against measurement, compound 3: 3 percentage points above; low and high end bracket the measured number.
By their numbers in this assay, from the lowest: compounds 3 and 1 (each within the scatter of the next); then compound 2.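

In this assay, inverting the stereocentre at this saturated ring carbon amounts to a number 8 percentage points lower from compound 1 to compound 3 (within the scatter), so the read-out at this single concentration does not separate the two configurations. That step can be assigned to this one stereocentre, because nothing else differs between the two structures: the fact that compounds 1 and 3 differ only in the configuration as drawn. The earlier step, a number 42 percentage points higher from compound 1 to compound 2 (beyond the scatter), concerned a group exchange and gave no view of configuration at this position.

The compounds shown leave open whether the configuration at this ring carbon would matter with ((1,5-diaminopentyl)carbonyl)amino in place of hydroxy, since that group appears with only one configuration here. They also leave open how a simple amine or a carboxylic acid in place of that hydroxy would read in this assay.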